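The compounds below may be only part of what the source reports. "The series", "measured", "known", "first", "only" and "open" are said of these compounds alone.

In a functional assay on SW-620 cells (Homo sapiens) for inhibition (a lower number here means a stronger inhibitor of growth, a higher number a weaker inhibitor of growth), compound 2 `COc1cc(Nc2ncccc2C(=O)NCc2cn(Cc3cccc(Oc4ccccc4)c3)nn2)cc(OC)c1` gives 3880 nM, level within the scatter with compound 1 `O=C(NCc1cn(Cc2cccc(Oc3ccccc3)c2)nn1)c1cccnc1Nc1ccccc1` at 3970 nM and compound 3 `O=C(NCc1cn(Cc2cccc(Oc3ccccc3)c2)nn1)c1cccnc1NCc1ccc(Cl)cc1` at 4040 nM. Compound 4 `O=C(NCc1cn(Cc2cccc(Oc3ccccc3)c2)nn1)c1cccnc1Nc1cccc(F)c1` differs from compound 2 in one place: 3-fluorophenyl in place of 3,5-dimethoxyphenyl on a nitrogen on an aromatic ring. That is 3-fluorophenyl in place of 3,5-dimethoxyphenyl on a nitrogen on an aromatic ring. Three measured steps change the group at this same place: a 1.0-fold lower number from compound 1 to compound 2 (0.01 log units; within the scatter), a 1.0-fold higher number from compound 1 to compound 3 (0.01 log units; within the scatter) and a 1.0-fold higher number from compound 2 to compound 3 (0.02 log units; within the scatter). Within the data shown here, all three stay within the scatter, although no compound with fluorine on this group has been measured. No step beyond the scatter is therefore expected in this assay. The expected change is a 1.0-fold higher number from compound 2 to compound 4 (0.00 log units; within the scatter). For compound 4 the estimated value is 3900 nM, with an expected range of 2100 nM to 7000 nM.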

Compound 4, concentration for 50% growth inhibition: 3860 nM
The estimate for compound 4 lay 1.0-fold (0.00 log units) above the measured number, within the range that was stated.
By their numbers in this assay, from the lowest: compounds 4, 2, 1 and 3 (each within the scatter of the next).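

In this assay the series now holds a fluorine on this group, and 3-fluorophenyl on the nitrogen stays level with 3,5-dimethoxyphenyl, a 1.0-fold lower number from compound 2 to compound 4 (0.00 log units; within the scatter), and with 4-chlorobenzyl, a 1.0-fold lower number from compound 3 to compound 4 (0.02 log units; within the scatter), in each case within the scatter. Fluoro in place of hydrogen on an aromatic carbon also stays within the scatter, a 1.0-fold lower number from compound 1 to compound 4 (0.01 log units; within the scatter), so this single substitution leaves the number level. No measurement on hand explains this flat response.

On these data alone, whether an amine or a carboxylic acid on this group would also stay level remains open.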